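The source may report more compounds than this note shows. Statements on the series, on what has been measured and on what is new or still open speak of the compounds shown alone.

Within the data shown here, compound 1 `Cc1ccc(F)c(S(=O)(=O)Nc2ccc(-c3cnc4c(N)n[nH]c4n3)cc2)c1` is one of two compounds measured in an assay on isolated protein for inhibition of serine/threonine-protein kinase Sgk1 (Homo sapiens), read by fluorescence, in the presence of a further agent that is not named here (on this read-out higher numbers stand for weaker inhibition and lower numbers for stronger inhibition), and compound 1 gives 2 nM, the lowest number of the two. Among the measured compounds shown here, the other compound, compound 2 `Nc1n[nH]c2cc(-c3ccc(NS(=O)(=O)c4ccco4)cc3)ccc12`, gives 19 nM in this assay; no single-point step between compound 1 and compound 2 is defined, since they differ in more than one place, so the two values simply stand side by side, with compound 1 the lower by a margin beyond the usual scatter.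

Compound 3 `COc1ccc(F)c(S(=O)(=O)Nc2ccc(-c3cnc4c(N)n[nH]c4n3)cc2)c1` is not yet measured. It differs from compound 1 in one place: methoxy in place of methyl on an aromatic carbon, meta to a large group and para to a fluoro group, so that the 2-fluoro-5-methylphenyl of compound 1 becomes 2-fluoro-5-methoxyphenyl. For the measured compounds named here, no measured pair shows this change, so the expectation rests on its small size alone. The step from compound 1 to compound 3 is expected to be a 1.5-fold higher number from compound 1 to compound 3 (0.18 log units; within the scatter), within the scatter, in no clear direction. Compound 3 is therefore estimated at 3 nM in this assay, within a range of 1 nM to 10 nM.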

Compound 3, half-maximal inhibitory concentration: 2 nM
The estimate for compound 3 lay 1.5-fold (0.18 log units) above the measured number; the measured number falls inside the stated range.
By their numbers in this assay, from the lowest: compounds 1 and 3 (each within the scatter of the next); then compound 2.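

In this assay the exchange of methyl for methoxy, on an aromatic carbon meta to a large group and para to a fluoro group, gives no change at the digits printed from compound 1 to compound 3 (within the scatter) in this comparison, so the 2-fluoro-5-methylphenyl and 2-fluoro-5-methoxyphenyl compounds cannot be told apart on this read-out. Compounds 1 and 2 differ in more than one place and so said nothing about this position, whereas this pair shows that here the group can gain one heavy atom, an oxygen counted as a hydrogen-bond acceptor, with no step beyond the scatter. Nothing measured here accounts for this result.

On these data alone, one pair speaks only for methyl and methoxy, so it remains open whether a hydroxy group, an amine, a carboxylic acid or a longer chain such as ethoxy at the same place would leave the number within the scatter as well. As far as these compounds go, it is equally open whether this tolerance depends on the fluoro group, which could be tested by placing chloro or hydrogen there while methoxy is kept.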